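Vinyl in Place of Chloromethyl on the Amide Carbonyl

The source may hold more compounds than are shown below. What is called first, only, known or untested is meant among the compounds shown, and "the series" means these compounds.

Compound 1 `C=CC(=O)Nc1cccc(-c2cn3c(C(=O)OCC)csc3n2)c1` reaches only a limit of a functional assay on MV4-11 cells (Homo sapiens) for cytotoxicity, read by MTT assay, with a stated time of 72 h (on this read-out higher numbers stand for weaker inhibition and lower numbers for stronger inhibition), namely > 20000 nM. Compound 2 `CCOC(=O)c1csc2nc(-c3cccc(NC(=O)CCl)c3)cn12` gives 17700 nM in this assay. Compound 3 `CCOC(=O)c1csc2nc(-c3ccc(NC(=O)CCl)cc3)cn12` gives 9070 nM in this assay.

For the measured compounds named here, the one measured step, an at least 1.1-fold higher number from compound 2 to compound 1 (0.05 log units; that floor lies within the scatter), comes from vinyl in place of chloromethyl on a carbonyl carbon; that it is only a floor follows from the limit of > 20000 nM in this assay, at which 1 of the 3 values shown sits. Compound 3 and compound 2 share the same atoms joined differently, and the difference between the two cores is not broken down here; their values lie within the scatter of each other. Compound 4 `C=CC(=O)Nc1ccc(-c2cn3c(C(=O)OCC)csc3n2)cc1` is not yet measured. It differs from compound 3 by vinyl in place of chloromethyl on a carbonyl carbon, the same change as that from compound 2 to compound 1, made on the same place. For compound 4 the step of a 1.8-fold higher number from compound 3 to compound 4 (0.25 log units; within the scatter) is expected, resting on compound 3 at 9070 nM and on the step of an at least 1.1-fold higher number from compound 2 to compound 1 (0.05 log units; that floor lies within the scatter). Compound 4 is therefore estimated at 16000 nM in this assay, between 7000 nM and 40000 nM.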

Compound 4, half-maximal inhibitory concentration: 2930 nM
The estimate for compound 4 lay 5.5-fold (0.74 log units) above the measured number; the measured number lies below the stated range.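

In this assay, vinyl in place of chloromethyl on the carbonyl carbon gives a 3.1-fold lower number from compound 3 to compound 4 (0.49 log units; beyond the scatter), so on the core of compound 3 this change goes with stronger inhibition. The change therefore does not carry over as one fixed step between the two cores, and its outcome here depends on the core that bears it: the same change on two cores in this assay, an at least 1.1-fold higher number (0.05 log units; that floor lies within the scatter) from compound 2 to compound 1 and a 3.1-fold lower number (0.49 log units; beyond the scatter) from compound 3 to compound 4, at least 3.4-fold (0.54 log units) apart, beyond the scatter of two such steps. Compound 1 stands at a limit and not at a number, so the true size of the step on its core remains unknown, and a single pair of cores gives no rule for any other core, nor a reason for the gap: the limit of > 20000 nM in this assay, at which 1 of the 4 values shown sits.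

From the compounds shown here alone, it remains open whether a longer chain or an aminomethyl group on the same carbonyl carbon would give numbers closer to compound 4 or to compound 3. Also open, going by these compounds, is whether the step from chloromethyl to vinyl would keep its size if the ethyl ester of the shared core gave way to a carboxylic acid.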